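The compounds below may be only part of what the source reports. "The series", "measured", "known", "first", "only" and "open" are said of these compounds alone.

Working notes on the series. Compound 1 `O=C(Nc1ccccc1)c1ccc(-c2ncccc2C(F)(F)F)cc1` carries the shared core with an unsubstituted phenyl amide; in a functional assay for antagonist activity at transient receptor potential cation channel subfamily V member 1 (Rattus norvegicus) (a higher number here means a weaker inhibitor, a lower number a stronger inhibitor), compound 1 gives "not determined" (no result reported), that is, no reported result. Compound 2 `N#Cc1ccc(NC(=O)c2ccc(-c3ncccc3C(F)(F)F)cc2)cc1` and compound 3 `CC(C)(C)c1ccc(NC(=O)c2ccc(-c3ncccc3C#N)cc2)cc1` differ from each other at two places, so their values are only placed side by side: in this assay compound 2 gives 1300 nM, and compound 3 gives 13 nM, the lowest of the two numbers and a gap beyond the usual scatter. Within what has been measured, compound 3 is the reference point for the next compound.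

Compound 4 `CC(C)(C)c1ccc(NC(=O)c2ccc(-c3ncccc3N(S(C)(=O)=O)S(C)(=O)=O)cc2)cc1` is not yet measured. It differs from compound 3 in one place: bis(methylsulfonyl)amino in place of cyano on an aromatic carbon, ortho to a large group and two atoms from the ring nitrogen. Among the measured compounds shown here, no measured pair shows this kind of exchange, so there is no step to lean on. The change is expected to raise the number in this assay by about a 12-fold higher number from compound 3 to compound 4 (1.06 log units; beyond the scatter), with wide uncertainty. For compound 4 the estimated value in this assay is 150 nM, expected to fall between 20 nM and 1500 nM.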

Compound 4, half-maximal inhibitory concentration: 0.4 nM
Estimate against measurement, compound 4: 380-fold (2.57 log units) above, and the stated range ends above it.
By their numbers in this assay, from the lowest: compound 4; then compound 3; then compound 2.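

At this position, ortho to a large group and two atoms from the ring nitrogen, a much larger group than cyano is compatible with strong inhibition: in this assay, bis(methylsulfonyl)amino in place of cyano gives a 33-fold lower number from compound 3 to compound 4 (1.51 log units; beyond the scatter). The entering group brings 9 heavy atoms against 2 and 4 hydrogen-bond acceptors against 1, but this single pair cannot separate those differences or tie the step to either one. No measurement available here explains the step.

The compounds shown leave open how a single methylsulfonylamino group, a free amine or a carboxylic acid on this aromatic carbon would compare in this assay. They also leave open whether both methylsulfonyl groups are needed for the lower number of compound 4.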